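Dropping the fluoro from the sulfonyl aryl ring

A few compounds are considered here, and "the series" means these few. Any claim that something is new, unique, unknown or untested is made for them only; others in the source may bear on it.

Compound 1, `CCOC(=O)c1oc2ccc(N(Cc3ccccc3)S(=O)(=O)c3cccc(Br)c3)cc2c1C`: in a functional assay on HCT-116 cells (Homo sapiens) for inhibition, read by MTT assay, with a stated time of 72 h (on this read-out lower numbers stand for stronger inhibition and higher numbers for weaker inhibition), compound 1 reaches only the assay limit of > 40000 nM.
Compound 2, `CCOC(=O)c1oc2ccc(N(Cc3ccccc3)S(=O)(=O)c3ccc(F)cc3)cc2c1C`: in this assay compound 2 gives 33100 nM.

Going by the values given here, compound 2 holds the only numerical value in this assay; the value of compound 1 is a limit, as the limit of > 40000 nM in this assay, at which 1 of the 2 values shown sits, records. Among the compounds with values here, the single measured step, an at least 1.2-fold lower number from compound 1 to compound 2 (0.08 log units; that floor lies within the scatter), is itself bounded by that limit and is not known to go beyond the scatter.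

Compound 3, `CCOC(=O)c1oc2ccc(N(Cc3ccccc3)S(=O)(=O)c3ccccc3)cc2c1C`, differs from compound 2 by hydrogen in place of fluoro on an aromatic carbon. That change touches the same sulfonyl aryl ring that the step from compound 1 to compound 2 altered, and that step gave no clear movement. Within the data shown here, no measured step shows a hydrogen taking the place of a fluoro on this ring, so the expectation rests on the weak precedent alone.

For compound 3 in this assay a number close to that of compound 2 is expected, that is a step of a 1.2-fold higher number from compound 2 to compound 3 (0.08 log units; within the scatter), with the estimate 40000 nM between 15000 nM and 110000 nM.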

Compound 3, half-maximal inhibitory concentration: > 40000 nM
Compound 3: only a limit was reported; the forecaster's own chance of this, stated with the estimate: 50%; the middle value sits exactly at the limit.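

In this assay compound 3, which carries the plain phenyl on the sulfonyl sulfur, reaches only a limit, > 40000 nM. Removing the fluoro gives an at least 1.2-fold higher number from compound 2 to compound 3 (0.08 log units; that floor lies within the scatter), so this change is not shown to move the number beyond the scatter, and compound 2 remains the only one of the three with a numerical value. The steps between compounds that both sit at the limit cannot be read, and the limit now holds most of the set: the limit of > 40000 nM in this assay, at which 2 of the 3 values shown sit.

As far as these compounds go, it remains open whether a methoxy group or an amine on this sulfonyl aryl ring would bring a number clearly lower than that of compound 2. From the compounds shown here alone, how far the true values of compound 1 and compound 3 lie past the limit also remains open.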